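A few compounds are considered here, and "the series" means these few. Any claim that something is new, unique, unknown or untested is made for them only; others in the source may bear on it.

Working notes on the series in a functional assay on AGS cells (Homo sapiens) for cytotoxicity, read by MTT assay; on this read-out lower numbers stand for stronger inhibition and higher numbers for weaker inhibition. Compound 1 `C=C[C@@](C)(/C=C/c1ccc(OC(C)(C)[C@@H](O)CC[C@@](C)(C=C)/C=C/c2ccc(O)cc2)cc1)CCC=C(C)C` reads > 50000 nM, which is a limit of the assay. Compound 2 `C=C[C@@](C)(/C=C/c1ccc(O)cc1)CCC1OC1(C)C` reads > 50000 nM, also a limit. Taken together, the series so far shows (the limit of > 50000 nM in this assay, at which 2 of the 3 values shown sit). Among the compounds with values here, compound 3 `C=C[C@@](C)(/C=C/c1ccc(OC(C)=O)cc1)CCC=C(C)C` gives 26800 nM, the only actual number available, so it stands alone as the sole measured reference point.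

The next compound is compound 4 `C=C[C@@](C)(/C=C/c1ccc(OC)cc1)CCC=C(C)C`, with methyl in place of acetyl on an oxygen on an aromatic ring, that is, acetoxy to methoxy: methyl in place of acetyl on an oxygen on an aromatic ring. Within the data shown here, no measured pair isolates a change of this kind, so the expectation rests on compound 3 at 26800 nM alone. No shift beyond the usual scatter is expected, and no direction is favoured: the estimated change is a 1.1-fold higher number from compound 3 to compound 4 (0.05 log units; within the scatter). A result reported only as a limit remains a real possibility. Compound 4 is estimated at 30000 nM, with an expected range of 14000 nM to 50000 nM.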

Compound 4, half-maximal inhibitory concentration: 55800 nM
For compound 4 the middle estimate is 1.9-fold (0.27 log units) below the measured one; the measured number lies above the stated range.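

In this assay, within the data shown here, the change from acetoxy to methoxy gives the first readable step (a 2.1-fold higher number from compound 3 to compound 4 (0.32 log units; beyond the scatter)), a modest shift that lies beyond the scatter. This shows that the group on an oxygen on an aromatic ring affects the read-out, with acetyl giving the lower number of this pair, although both numbers remain high. This single pair carries the finding, and no further step can be read from the other values: the limit of > 50000 nM in this assay, at which 2 of the 4 values shown sit.

Going by these compounds, whether a longer acyl chain such as butyryl, or a carbamate bearing an amine, on the same oxygen would lower the number remains open. One pair also cannot show whether the direction of this step holds on any other core.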